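The source may hold more compounds than are shown below. What is called first, only, known or untested is meant among the compounds shown, and "the series" means these compounds.

Among the compounds with values here, in a functional assay on HepG2 cells (Homo sapiens) for inhibition, read by MTT assay, with a stated time of 72 h (on this read-out lower numbers stand for stronger inhibition and higher numbers for weaker inhibition), compound 3 `CC(C)(C)n1cc2c(n1)C(=O)CC1(CCN(C(=O)c3cc(-c4ccc(N)cc4)nc4ccccc34)CC1)O2` gives 630 nM as the lowest number so far. Compound 1 `Cc1ccc(-c2cc(C(=O)N3CCC4(CC3)CC(=O)c3nn(C(C)(C)C)cc3O4)c3ccccc3n2)cc1` gives 1440 nM and so sits higher. Compound 2 `CC(C)(C)n1cc2c(n1)C(=O)CC1(CCN(C(=O)c3cc(-c4ccccc4Cl)nc4ccccc34)CC1)O2` reads > 10000 nM as a limit of the assay and not a number. Compound 4 `CC(C)(C)n1cc2c(n1)C(=O)CC1(CCN(C(=O)c3cc(-c4ccncc4)nc4ccccc34)CC1)O2` carries pyridin-4-yl in place of 4-aminophenyl on an aromatic carbon. Within the data shown here, no measured step makes this exact swap. The nearest guide is amino in place of methyl (a 2.3-fold lower number from compound 1 to compound 3 (0.36 log units; beyond the scatter)), so compound 4, lacking that amino group, may give a modestly higher number. The swap to 2-chlorophenyl (an at least 6.9-fold higher number from compound 1 to compound 2 (0.84 log units; beyond the scatter)) shows that changing this group can shift the number much further, so the range stays wide on the high side. The expected change is a modest one (a 2.4-fold higher number from compound 3 to compound 4 (0.38 log units; beyond the scatter)). The estimate for compound 4 is 1500 nM (500 nM to 6000 nM).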

Compound 4, half-maximal inhibitory concentration: 380 nM
Estimate against measurement, compound 4: 3.9-fold (0.60 log units) above; measured number outside the range, below it.
By their numbers in this assay, from the lowest: compounds 4 and 3 (each within the scatter of the next); then compound 1. At a limit, above all of these: compound 2.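

In this assay, pyridin-4-yl and 4-aminophenyl cannot be told apart at this position (a 1.7-fold lower number from compound 3 to compound 4 (0.22 log units; within the scatter)), so the amino group is not needed for a number in this range. Pyridin-4-yl also improves on 4-methylphenyl (a 3.8-fold lower number from compound 1 to compound 4 (0.58 log units; beyond the scatter)), which shows that a ring with no hydrogen-bond donor can do better than the 4-methylphenyl ring here. The remaining step (an at least 26-fold lower number from compound 2 to compound 4 (1.42 log units; beyond the scatter)) starts from a limit of the assay and not a number: the limit of > 10000 nM in this assay, at which 1 of the 4 values shown sits.

On these data alone, whether the place of the ring nitrogen matters remains open, and pyridin-3-yl would test it. As far as these compounds go, whether chlorine itself is tolerated also remains open, and 4-chlorophenyl would test that.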